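A longer carbamate-bearing chain: what to expect for compound 3

The source may hold more compounds than are shown below. What is called first, only, known or untested is meant among the compounds shown, and "the series" means these compounds.

In an assay on HEK293 cells for displacement of a labelled ligand from NPC1-like intracellular cholesterol transporter 1 (Homo sapiens) (on this read-out lower numbers stand for stronger inhibition and higher numbers for weaker inhibition), compound 1 `CC(C)(C)OC(=O)NCCNC(=O)CN1CN(c2ccccc2)C2(CCN(C(=O)c3ccc(C4CCCCC4)cc3)CC2)C1=O` gives 5500 nM, and compound 2 `COC(=O)CCCNC(=O)CN1CN(c2ccccc2)C2(CCN(C(=O)c3ccc(C4CCCCC4)cc3)CC2)C1=O` gives 2500 nM, the lower of the two numbers shown, with a 2.2-fold lower number from compound 1 to compound 2 (0.34 log units; beyond the scatter). Compound 3 `CC(C)(C)OC(=O)NCCCCNC(=O)CN1CN(c2ccccc2)C2(CCN(C(=O)c3ccc(C4CCCCC4)cc3)CC2)C1=O` differs from compound 2 by ((tert-butoxycarbonyl)amino)methyl in place of methoxycarbonyl on a saturated chain carbon, three bonds along the chain from an amide-type nitrogen. Within the data shown here, only that single measured step bears on this change, and it ran in the opposite direction at a modest size, so a modest rise in the number is expected, possibly not beyond the scatter. Compound 3 is therefore expected to give about 4000 nM (range 1500 nM to 11000 nM), meaning a 1.6-fold higher number from compound 2 to compound 3 (0.20 log units; within the scatter).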

Compound 3, half-maximal inhibitory concentration: 4600 nM
Compound 3: middle estimate off by 1.2-fold (0.06 log units), on the low side; the range from low to high includes it.
By their numbers in this assay, from the lowest: compounds 2, 3 and 1 (each within the scatter of the next, the first and the last beyond it).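

In this assay, 2-((tert-butoxycarbonyl)amino)ethyl in place of (tert-butoxycarbonyl)amino gives a 1.2-fold lower number from compound 1 to compound 3 (0.08 log units; within the scatter), so at this position the longer carbamate chain cannot be told apart from the shorter one. Swapping methoxycarbonyl for ((tert-butoxycarbonyl)amino)methyl gives a 1.8-fold higher number from compound 2 to compound 3 (0.26 log units; within the scatter), so compound 3 cannot be separated from either neighbour, and only the gap between compound 1 and compound 2 remains beyond the scatter. On these data alone, whether a free amine or a carboxylic acid at the chain end, or a still longer chain, would move the number stays open. Nothing given here accounts for these values.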